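A few compounds are considered here, and "the series" means these few. Any claim that something is new, unique, unknown or untested is made for them only; others in the source may bear on it.

Compound 2 `O=S(=O)(c1cccc(F)c1)c1ccc2c(c1)CCC[C@H]2CNCCO` and compound 1 `O=C(NC[C@@H]1CCCc2cc(S(=O)(=O)c3cccc(F)c3)ccc21)c1ccc[nH]1` share one core and differ only at the amine nitrogen on the side chain. In an assay on isolated protein for displacement of a labelled ligand from 5-hydroxytryptamine receptor 6 (Homo sapiens) (on this read-out lower numbers stand for stronger inhibition and higher numbers for weaker inhibition), compound 1 gives 5.01 nM, while compound 2 gives 0.126 nM, the lower of the two numbers recorded so far. Going by the values given here, that single change, a 40-fold lower number from compound 1 to compound 2 (1.60 log units; beyond the scatter), is the only measured step available. Compound 3 `CC(C)(C)C(=O)NC[C@@H]1CCCc2cc(S(=O)(=O)c3cccc(F)c3)ccc21` now replaces the group on that nitrogen again: (tert-butyl)carbonyl in place of 2-hydroxyethyl on an amine nitrogen. Like compound 1, compound 3 carries a carbonyl on the nitrogen rather than a 2-hydroxyethyl chain, and the one measured step ran strongly in favour of the 2-hydroxyethyl group. A move in the opposite direction, of roughly that size, is therefore expected, so compound 3 is estimated at a 50-fold higher number from compound 2 to compound 3 (1.70 log units; beyond the scatter). On that basis compound 3 is expected to give about 6.3 nM in this assay, somewhere between 1.5 nM and 25 nM.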

Compound 3, inhibition constant: 3.98 nM
Compound 3: middle estimate off by 1.6-fold (0.20 log units), on the high side; the range from low to high includes it.
By their numbers in this assay, from the lowest: compound 2; then compounds 3 and 1 (each within the scatter of the next).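

In this assay, a second carbonyl group on the amine nitrogen gives a 32-fold higher number from compound 2 to compound 3 (1.50 log units; beyond the scatter), so the large gap to the 2-hydroxyethyl compound is not peculiar to the 1H-pyrrol-2-yl group of compound 1. Changing what sits on the carbonyl carbon makes no clear difference, with a 1.3-fold lower number from compound 1 to compound 3 (0.10 log units; within the scatter) inside the usual scatter, so tert-butyl and 1H-pyrrol-2-yl cannot be told apart at this position. No supporting data explain why these two carbonyl compounds stand apart from compound 2.

As far as these compounds go, it stays open whether the gap follows the presence of the carbonyl or the loss of the hydroxyl of the 2-hydroxyethyl chain. A plain ethyl group on that nitrogen, a free amine or a 3-hydroxypropyl chain would help separate these two readings.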